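Chloro on the Styryl Ring of a Trimethoxy Chalcone

The source may hold more compounds than are shown below. What is called first, only, known or untested is meant among the compounds shown, and "the series" means these compounds.

Measured so far:
Compound 1 `COc1cc(OC)c(C(=O)/C=C/c2ccccc2SC)c(OC)c1` gives 48% in a functional assay on MDA-MB-231 cells (Homo sapiens), read by fluorescence and BrdU incorporation, with a stated time of 48 h, tested at 10 uM; a higher number here means a weaker effect of the compound at the concentration tested, a lower number a stronger effect.
Compound 2 `COc1cc(OC)c(C(=O)/C=C/c2ccccc2)c(OC)c1` gives 37% in this assay.

Compound 2 stands lowest of the two numbers; compound 1 is nearest, and the step of a number 11 percentage points lower from compound 1 to compound 2 (beyond the scatter) is the only one measured. Compound 3 `COc1cc(OC)c(C(=O)/C=C/c2ccc(Cl)cc2)c(OC)c1` differs from compound 2 by chloro in place of hydrogen on an aromatic carbon. For the measured compounds named here, no measured step exchanges chloro for hydrogen, so the single step from compound 1 to compound 2 bears only loosely on it, and it was modest. The change to compound 3 is therefore expected to stay within the scatter of this assay, the step of a number 1 percentage points higher from compound 2 to compound 3 (within the scatter) carrying no clear direction. Compound 3 is estimated at 38%, within 22% to 55%.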

Compound 3, a percentage reported as activity, at one concentration (the size of the read-out at that concentration, not a potency): 39%
For compound 3 the middle estimate is 1 percentage points below the measured one; low and high end bracket the measured number.
By their numbers in this assay, from the lowest: compounds 2, 3 and 1 (each within the scatter of the next, the first and the last beyond it).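

Chloro in place of hydrogen, on an aromatic carbon para to a large group, gives a number 2 percentage points higher from compound 2 to compound 3 (within the scatter) in this assay, so the two substituents cannot be told apart here. The exchange of 2-(methylsulfanyl)phenyl for 4-chlorophenyl gives a number 9 percentage points lower from compound 1 to compound 3 (within the scatter), a step that, unlike the one to the unsubstituted phenyl, stays inside the scatter. No evidence at hand accounts for either step.

From the compounds shown here alone, whether an amine or a carboxylic acid at this place would give a step beyond the scatter remains open. So does the effect of chloro on the other aromatic carbons of this ring.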